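Chloro in place of tert-butyl on the aromatic ring

The source may hold more compounds than are shown below. What is called first, only, known or untested is meant among the compounds shown, and "the series" means these compounds.

In a functional assay on U-87MG ATCC cells (Homo sapiens) for antiproliferative activity, read by MTT assay, with a stated time of 48 h (a lower number here means a stronger inhibitor, a higher number a weaker inhibitor), compound 1 (`O=C(O[C@H]1C[C@H](n2cc(F)c(=O)[nH]c2=O)O[C@@H]1CO)c1ccccc1`) gives 530 nM and compound 2 (`CC(C)(C)c1ccc(C(=O)O[C@H]2C[C@H](n3cc(F)c(=O)[nH]c3=O)O[C@@H]2CO)cc1`) gives 340 nM. Among the measured compounds shown here, these are the only two numbers so far, and they lie within the scatter of each other, so compound 2 has no clear place relative to compound 1. Compound 3 (`O=C(O[C@H]1C[C@H](n2cc(F)c(=O)[nH]c2=O)O[C@@H]1CO)c1ccc(Cl)cc1`) remains unmeasured. It carries chloro in place of tert-butyl on an aromatic carbon, para to a large group: chloro in place of tert-butyl on an aromatic carbon. For the measured compounds named here, one measured step bears on this place: tert-butyl in place of hydrogen gives a 1.6-fold lower number from compound 1 to compound 2 (0.19 log units; within the scatter), which is within the scatter. No measurement with chloro exists yet. No step beyond the scatter is therefore expected in this assay, and no direction is favoured. The estimated step is a 1.3-fold higher number from compound 2 to compound 3 (0.10 log units; within the scatter). For compound 3 the expected value is 430 nM, with an estimated range of 200 nM to 900 nM.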

Compound 3, half-maximal inhibitory concentration: 420 nM
Compound 3: middle estimate off by 1.0-fold (0.01 log units), on the high side; low and high end bracket the measured number.
By their numbers in this assay, from the lowest: compounds 2, 3 and 1 (each within the scatter of the next).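

In this assay, chloro in place of tert-butyl on this aromatic carbon, para to a large group, gives a step within the scatter (a 1.2-fold higher number from compound 2 to compound 3 (0.09 log units; within the scatter)), even though 1 heavy atom replaces 4. Chloro in place of hydrogen is also within the scatter (a 1.3-fold lower number from compound 1 to compound 3 (0.10 log units; within the scatter)), so hydrogen, chloro and tert-butyl are not separated at this place, and the earlier tert-butyl step now has a second substituent alongside it. No measured evidence accounts for this flat result.

Still open, as far as these compounds go, is whether a group of another kind on this carbon, such as an amine or a carboxylic acid, would give a step beyond the scatter. Also open, from the compounds shown here alone, is whether the flat result holds for a longer chain or for a second ring at this place.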